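The source may report more compounds than this note shows. Statements on the series, on what has been measured and on what is new or still open speak of the compounds shown alone.

Measured in an ADME assay on Vero 76 cells (Chlorocebus sabaeus) for cytotoxicity, read by MTT assay, with a stated time of 96 h; a higher number here means that more compound is tolerated, a lower number that less compound is tolerated:
- compound 1 `FC(F)(F)c1ccc(NCc2cn(-c3ccccc3)nc2-c2ccc(Br)cc2)cc1` gives 28000 nM
- compound 2 `Cc1ccc(-c2nn(-c3ccccc3)cc2CNc2ccc(Br)cc2)cc1` gives 92000 nM
- compound 3 `Cc1ccc(-c2nn(-c3ccccc3)cc2CNc2ccccc2)cc1` gives 52000 nM

The value of compound 3 lies within the scatter of those of compound 2 and compound 1. Compound 4 `Cc1ccc(-c2nn(-c3ccccc3)cc2CNc2ccc(C(F)(F)F)cc2)cc1` has trifluoromethyl in place of hydrogen on an aromatic carbon of compound 3 (trifluoromethyl in place of hydrogen on an aromatic carbon), para to a large group. Among the measured compounds shown here, the only measured step of this kind, hydrogen in place of bromo, is small (a 1.8-fold lower number from compound 2 to compound 3 (0.25 log units; within the scatter)). Compound 1, which also carries 4-(trifluoromethyl)phenyl, gives 28000 nM as its value. No step beyond the scatter is therefore expected in this assay, with a lower number slightly more likely than a higher one. The expected change is small (a 1.3-fold lower number from compound 3 to compound 4 (0.11 log units; within the scatter)). For compound 4 the estimated value is 40000 nM, with an expected range of 16000 nM to 95000 nM.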

Compound 4, half-maximal cytotoxic concentration: 45000 nM
Beside the measured number, compound 4's estimate is 1.1-fold (0.05 log units) below it; measured number inside the range.
By their numbers in this assay, from the lowest: compounds 1, 4, 3 and 2 (each within the scatter of the next, the first and the last beyond it).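

In this assay, trifluoromethyl in place of hydrogen on the aromatic carbon para to a large group gives only a 1.2-fold lower number from compound 3 to compound 4 (0.06 log units; within the scatter), so this position tolerates four extra heavy atoms with no step beyond the scatter. Trifluoromethyl in place of bromo at the same place gives a 2.0-fold lower number from compound 2 to compound 4 (0.31 log units; beyond the scatter), the first modest step beyond the scatter here, while methyl in place of bromo on an aromatic carbon gives a 1.6-fold higher number from compound 1 to compound 4 (0.21 log units; within the scatter). No available evidence bears on these steps. From the compounds shown here alone, whether an amine or a carboxylic acid at this position would give a larger step remains open.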